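The source may hold more compounds than are shown below. What is called first, only, known or untested is meant among the compounds shown, and "the series" means these compounds.

Measured compounds:
- compound 1, `CCS(=O)(=O)Nc1cccc2c1CCCC2c1c[nH]cn1`: 1320 nM
- compound 2, `CCS(=O)(=O)Nc1cc(Cl)cc2c1CCCC2c1c[nH]cn1`: < 10000 nM

Among the compounds with values here, in an assay on isolated protein (Cricetulus griseus) for binding affinity to Alpha-1B adrenergic receptor (Mesocricetus auratus), read by radioligand binding (a higher number here means a weaker inhibitor, a lower number a stronger inhibitor), compound 1 gives 1320 nM, the only number in the set. For compound 2 the result is not a number but a limit, < 10000 nM, as the limit of < 10000 nM in this assay, at which 1 of the 2 values shown sits, records. The step that the limit leaves unreadable from compound 1 to compound 2 therefore cannot be read.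

Compound 3, `Nc1cccc2c1CCCC2c1c[nH]cn1`, differs from compound 1 by hydrogen in place of ethylsulfonyl on a nitrogen on an aromatic ring. Within the data shown here, no measured step touches this change: the single comparison in hand concerns chloro in place of hydrogen on an aromatic carbon, and its size is hidden by the limit. What compound 3 will do in this assay thus has to be estimated without a guide from the measured compounds. The removal of the ethylsulfonyl group is a large change in structure, so a step beyond the scatter is plausible in either direction, and the estimate is kept wide. Compound 3 is expected to show the step of a 2.3-fold higher number from compound 1 to compound 3 (0.36 log units; beyond the scatter), giving an estimated value of 3000 nM with a range from 600 nM to 15000 nM.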

Compound 3, inhibition constant: 525 nM
For compound 3 the middle estimate is 5.7-fold (0.76 log units) above the measured one; measured number below the stated range.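

In this assay, within the data shown here, putting hydrogen in place of ethylsulfonyl on the nitrogen gives a 2.5-fold lower number from compound 1 to compound 3 (0.40 log units; beyond the scatter), the first step whose size can be read. It shows that, for this pair, the ethylsulfonyl group is not required for the affinity seen with compound 1, and that compound 3, with the simple amino group, is the stronger of the two, though the step is modest. Nothing in the data shown gives a reason for this step.

The compounds shown hold only the two ends of this change, and it stays open whether a methylsulfonyl group, an acetyl group or a single methyl on the same nitrogen would fall nearer to compound 1 or to compound 3. From the compounds shown here alone, compound 2 stands only as a limit, < 10000 nM, its step from compound 1 cannot be read, and what chloro in place of hydrogen on an aromatic carbon would do alongside the amino group remains open.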